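The source may hold more compounds than are shown below. What is called first, only, known or untested is meant among the compounds shown, and "the series" means these compounds.

Working notes, series of the shared core.

Going by the values given here, in an ADME assay on microsomes from liver (Rattus norvegicus) for metabolic stability, with a stated time of 10 min (a higher number here means that more of the compound is left, a lower number that less of the compound is left), compound 2 `CC(C)(C)NC(=O)NCCS(=O)(=O)NC(=O)c1ccc(Nc2nc(NC3(c4ccc(Cl)cc4)CC3)nc(OCC(F)(F)F)n2)cc1` gives 93% and stands lowest of the three numbers so far; compound 1 `CC(C)S(=O)(=O)NC(=O)c1ccc(Nc2nc(NC3(c4ccc(Cl)cc4)CC3)nc(OCC(F)(F)F)n2)cc1` gives 96% and compound 3 `CC(=O)NCCS(=O)(=O)NC(=O)c1ccc(Nc2nc(NC3(c4ccc(Cl)cc4)CC3)nc(OCC(F)(F)F)n2)cc1` gives 100%, yet the steps of a number 3 percentage points lower from compound 1 to compound 2 (within the scatter) and a number 7 percentage points higher from compound 2 to compound 3 (within the scatter) both lie within the scatter, as does a number 4 percentage points higher from compound 1 to compound 3 (within the scatter). Compound 4 `NCCS(=O)(=O)NC(=O)c1ccc(Nc2nc(NC3(c4ccc(Cl)cc4)CC3)nc(OCC(F)(F)F)n2)cc1` is not yet measured. The change from compound 2 is hydrogen in place of (tert-butyl)carbamoyl on an amine nitrogen. The step that bears on it most is a number 7 percentage points higher from compound 2 to compound 3 (within the scatter), which also trims the urea end of the chain; the swaps of the whole sulfonyl substituent, a number 3 percentage points lower from compound 1 to compound 2 (within the scatter) and a number 4 percentage points higher from compound 1 to compound 3 (within the scatter), are equally flat. No step beyond the scatter is therefore expected. The expected step is a number 2 percentage points higher from compound 2 to compound 4 (within the scatter). Compound 4 is expected to give 95%, with a range from 85% to 100%.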

Compound 4, percent of the compound remaining: 100%
Compound 4: the middle estimate sits 5 percentage points below what was measured, and the stated range covers the measured number.
By their numbers in this assay, from the lowest: compounds 2, 1, 3 and 4 (each within the scatter of the next).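

With hydrogen in place of (tert-butyl)carbamoyl on the amine nitrogen, this assay gives a number 7 percentage points higher from compound 2 to compound 4 (within the scatter), and with hydrogen in place of acetyl it gives no change at the digits printed from compound 3 to compound 4 (within the scatter), so the uncapped amine reads the same as both capped forms. With 2-aminoethyl in place of isopropyl on the sulfonyl sulfur, the step is a number 4 percentage points higher from compound 1 to compound 4 (within the scatter), so the bare chain is also level with the isopropyl compound. Nothing at hand explains this flatness. The compounds shown leave open whether a carboxylic acid at the chain end, a tertiary amine or a longer chain would stay within the scatter of these numbers.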